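Swapping an octyl chain for a chlorophenyl ring

This account rests on a few compounds, and the source may have more. Where it says the series, first, only, none or still open, it means among the compounds named here.

Compound 1, with structure `CCCCCCCCNc1nc(SCc2ccc(C(F)(F)F)cc2)nc2ccccc12`, carries an octyl chain on a nitrogen on an aromatic ring. In a functional assay on MGC-803 cells (Homo sapiens) for cytotoxicity, read by MTT assay, with a stated time of 72 h (on this read-out lower numbers stand for stronger inhibition and higher numbers for weaker inhibition), compound 1 gives 12600 nM, which is the lowest of the two numbers shown here. Compound 3, with structure `FC(F)(F)c1ccc(CSc2nc(Nc3cccc(C(F)(F)F)c3)c3ccccc3n2)cc1`, gives 15100 nM in this assay, and the step of a 1.2-fold higher number from compound 1 to compound 3 (0.08 log units; within the scatter) lies within the scatter. Compound 2, with structure `FC(F)(F)c1ccc(CSc2nc(Nc3ccccc3Cl)c3ccccc3n2)cc1`, reaches only a limit of the assay, > 50000 nM, so no number is known for it. The step of an at least 3.9-fold higher number from compound 1 to compound 2 (0.59 log units; beyond the scatter) therefore shows a loss, and an at least 3.3-fold lower number from compound 2 to compound 3 (0.51 log units; beyond the scatter) shows that 3-(trifluoromethyl)phenyl is at least modestly better than 2-chlorophenyl.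

Compound 4 has structure `FC(F)(F)c1ccc(CSc2nc(Nc3cccc(Cl)c3)c3ccccc3n2)cc1` and differs from compound 1 as follows: 3-chlorophenyl in place of octyl on a nitrogen on an aromatic ring. Within the data shown here, two measured steps bear on it: replacing octyl with 2-chlorophenyl cost at least modestly, while replacing it with 3-(trifluoromethyl)phenyl changed nothing beyond the scatter. Since 3-chlorophenyl is named like 3-(trifluoromethyl)phenyl rather than like 2-chlorophenyl, a change close to the scatter is expected, perhaps leaning to a slightly higher number. Compound 4 is therefore expected to give 17000 nM, within a range from 7000 nM to 45000 nM, which means an expected step of a 1.3-fold higher number from compound 1 to compound 4 (0.13 log units; within the scatter).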

Compound 4, half-maximal inhibitory concentration: 14600 nM
The estimate for compound 4 lay 1.2-fold (0.07 log units) above the measured number, within the range that was stated.
By their numbers in this assay, from the lowest: compounds 1, 4 and 3 (each within the scatter of the next). At a limit, above all of these: compound 2.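

In this assay, among these compounds, 3-chlorophenyl in place of 2-chlorophenyl gives an at least 3.4-fold lower number from compound 2 to compound 4 (0.53 log units; beyond the scatter) and, with the same chlorine-bearing ring on both sides, this is the first pair to show that where the chlorine sits on that ring matters, although compound 2 stands at a limit of the assay and not at a number: the limit of > 50000 nM in this assay, at which 1 of the 4 values shown sits. Chloro in place of trifluoromethyl on an aromatic carbon gives a 1.0-fold lower number from compound 3 to compound 4 (0.01 log units; within the scatter) and so, on the evidence of this single pair, the two groups cannot be told apart here. 3-chlorophenyl in place of octyl gives a 1.2-fold higher number from compound 1 to compound 4 (0.06 log units; within the scatter) and this adds a second aromatic ring that cannot be told apart from the octyl chain on this nitrogen, leaving compound 2 as the one case shown that goes against this.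

On these data alone, how a ring carrying a methoxy group or a carboxylic acid, or a chain shorter or longer than octyl, would read on this nitrogen remains open. Also open is whether the loss with 2-chlorophenyl belongs to chlorine alone or would follow a different group on the ring, since compound 2 is the only such case shown.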